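The compounds below may be only part of what the source reports. "The series", "measured", "known", "first", "only" and "open" are said of these compounds alone.

Measured in a toxicity assay on MDCK cells (Canis lupus familiaris) for cytotoxicity, read by crystal violet staining, with a stated time of 48 h; on this read-out higher numbers stand for lower toxicity in this test and lower numbers for higher toxicity in this test:
Compound 1 `Cc1ccc2[nH]c(=O)c(CN(Cc3ccc(F)cc3)Cc3cccc4ccccc34)cc2c1`: > 5000 nM, a limit of the assay.
Compound 2 `CCc1ccc2[nH]c(=O)c(CN(Cc3ccc(F)cc3)Cc3cccc4ccccc34)cc2c1`: > 5000 nM, a limit of the assay.
Compound 3 `Cc1ccc2[nH]c(=O)c(CN(Cc3ccc(O)cc3)Cc3ccc(C(C)(C)C)cc3)cc2c1`: 4900 nM.

Within the data shown here, compound 3 supplies the only number; the other two values sit at the limit of > 5000 nM in this assay, at which 2 of the 3 values shown sit. The difference between the core of compound 1 and the core of compound 3 is not broken down here. The change methyl in place of hydrogen on a saturated chain carbon bound to an aromatic carbon gives a step that the two limits leave unreadable from compound 1 to compound 2 in this assay, so its size cannot be read. Compound 4 `CCc1ccc2[nH]c(=O)c(CN(Cc3ccc(O)cc3)Cc3ccc(C(C)(C)C)cc3)cc2c1` carries the same change against compound 3, (methyl in place of hydrogen on a saturated chain carbon bound to an aromatic carbon). Compound 3 gives 4900 nM, and the step that the two limits leave unreadable from compound 1 to compound 2 is unreadable, so little movement is expected. The step from compound 3 to compound 4 is estimated as a 1.0-fold higher number from compound 3 to compound 4 (0.01 log units; within the scatter). Compound 4 is estimated at 5000 nM, between 3000 nM and 8000 nM, and is likely to come back only as a limit.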

Compound 4, half-maximal cytotoxic concentration: > 10000 nM
Compound 4: only a limit was reported; the forecaster's own chance of this, stated with the estimate: 60%; middle value at least 2.0-fold (0.30 log units) from the limit.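

In this assay, methyl in place of hydrogen on a saturated chain carbon bound to an aromatic carbon gives an at least 2.0-fold higher number from compound 3 to compound 4 (0.30 log units; that floor lies within the scatter), and this floor is all that the pair fixes on the core of compound 3. Compound 4 gives > 10000 nM, which is a limit and not a number. Among these compounds, the step from compound 1 to compound 2 cannot be read, so the series offers no two sized steps to compare, and carrying the change from one core to the other is neither confirmed nor refuted.

Left open is how a propyl chain or a carboxylic acid in that same place would read in this assay. As far as these compounds go, the true value of compound 4 also remains open.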